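Oxazole ketone series: aryl substituent variation, compound 4 outlook

The compounds below may be only part of what the source reports. "The series", "measured", "known", "first", "only" and "open" are said of these compounds alone.

Measured compounds:
compound 1 `O=C(CCCCCCc1ccccc1)c1ncc(-c2cccc(O)c2)o1`, 50 nM
compound 2 `NC(=O)c1ccc(-c2cnc(C(=O)CCCCCCc3ccccc3)o2)cc1`, 10 nM
compound 3 `Cc1ccc(-c2cnc(C(=O)CCCCCCc3ccccc3)o2)nc1`, 2.8 nM

All three share the same core and were run in an assay (Rattus norvegicus) for inhibition of Fatty-acid amide hydrolase 1 (Homo sapiens); on this read-out lower numbers stand for stronger inhibition and higher numbers for weaker inhibition. Compound 1 carries the highest number of the three. Its nearest neighbour is compound 2, reached by a step of a 5.0-fold lower number from compound 1 to compound 2 (0.70 log units; beyond the scatter), and the furthest is compound 3, reached by an 18-fold lower number from compound 1 to compound 3 (1.25 log units; beyond the scatter). Between the two lower compounds the step from the carbamoylphenyl to the methylpyridinyl group is a 3.6-fold lower number from compound 2 to compound 3 (0.55 log units; beyond the scatter).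

Compound 4 `O=C(CCCCCCc1ccccc1)c1ncc(-c2ncccn2)o1` is not yet measured in this assay. Relative to compound 1 the change is pyrimidin-2-yl in place of 3-hydroxyphenyl on an aromatic carbon; the group enters on an aromatic carbon of the five-membered aromatic ring, next to the ring oxygen.

Among the measured compounds shown here, two measured steps bear on this change, both starting from compound 1 and both replacing the 3-hydroxyphenyl group with a different aromatic ring: the modest step to compound 2 and the large step to compound 3, the latter also bringing a ring with nitrogen. Compound 4 brings a six-membered ring with two nitrogens and no hydrogen-bond donor, most like the change to compound 3 but without the methyl group. The expected direction is therefore a lower number, of a size between the two measured steps.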

Compound 4, inhibition constant: 5.3 nM
Compound 4: the middle estimate sits 1.5-fold (0.18 log units) above what was measured, within the range that was stated.
By their numbers in this assay, from the lowest: compounds 3, 4 and 2 (each within the scatter of the next, the first and the last beyond it); then compound 1.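

In this assay, the pyrimidin-2-yl group gives a 9.4-fold lower number from compound 1 to compound 4 (0.97 log units; beyond the scatter), so a third replacement of 3-hydroxyphenyl at this aromatic carbon, next to the ring oxygen, ends beyond the scatter from compound 1, and the methyl group of compound 3 is not needed for that. Compound 4 cannot be told apart from either lower neighbour, with a 1.9-fold higher number from compound 3 to compound 4 (0.28 log units; within the scatter) and a 1.9-fold lower number from compound 2 to compound 4 (0.28 log units; within the scatter), so it does not separate compound 2 and compound 3 even though the gap between those two lies beyond the scatter. Nothing at hand accounts for any of these steps.

Still open, from the compounds shown here alone, is where a plain phenyl or an unsubstituted pyridin-2-yl ring would fall, which would show whether the distance from compound 1 tracks the loss of the hydroxyl group or the arrival of ring nitrogen. Also open, going by these compounds, is whether an amine or a carboxylic acid on the pyrimidin-2-yl ring, or a shorter chain between the ketone and the terminal phenyl, would keep the number near that of compound 4.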